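A few compounds are considered here, and "the series" means these few. Any claim that something is new, unique, unknown or untested is made for them only; others in the source may bear on it.

In a functional assay on Caco-2 cells (Homo sapiens) for antiproliferative activity, with a stated time of 48 h (on this read-out lower numbers stand for stronger inhibition and higher numbers for weaker inhibition), compound 1 (`CCN(CC)c1ccc(-c2cccc(OC)c2)nn1`) gives > 25000 nM, which is a limit of the assay and not a number. The other two measured members of the series sit at one level: compound 2 (`CC(=O)c1ccc(-c2ccc(N3CCCC3)nn2)cc1`) gives 50000 nM and compound 3 (`COc1ccc(Nc2ccc(-c3ccccc3)nn2)cc1`) gives 50000 nM. Next in line is compound 4 (`CCN(CC)c1ccc(-c2cccc(C(F)(F)F)c2)nn1`), which carries trifluoromethyl in place of methoxy on an aromatic carbon, meta to a large group: trifluoromethyl in place of methoxy on an aromatic carbon. For the measured compounds named here, no measured pair isolates a single change, so this assay offers no direct precedent for this replacement. Only weak inhibition has been seen so far, in compound 2 and compound 3 alike, and no step beyond the usual scatter is expected here. The expected step, an estimate only, is a step that the limit leaves unreadable from compound 1 to compound 4. A result reported only as a limit would be no surprise. For compound 4 the estimated value is 40000 nM, with an expected range of 15000 nM to 100000 nM.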

Compound 4, half-maximal inhibitory concentration: > 25000 nM
Compound 4: no number, only a limit; the forecaster's own chance of this, stated with the estimate: 50%; the middle value does not contradict the limit.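

In this assay compound 4 gives > 25000 nM, a limit of the assay and not a number, and compound 1 stands at the same limit, so no step can be read between them. As far as these compounds go, whether trifluoromethyl in place of methoxy on an aromatic carbon shifts the read-out at all remains open.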